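Swapping Furan for Thiophene: What Compound 3 Should Give

The source may report more compounds than this note shows. Statements on the series, on what has been measured and on what is new or still open speak of the compounds shown alone.

Measured compounds:
Compound 1 `CN1CCC[C@H]1COc1cncc(-c2ccc(F)cc2)c1`: 0.11 nM in an assay on membranes from brain for binding affinity to Neuronal acetylcholine receptor; alpha4/beta2 (Rattus norvegicus); on this read-out higher numbers stand for weaker inhibition and lower numbers for stronger inhibition
Compound 2 `CN1CCC[C@H]1COc1cncc(-c2ccco2)c1`: 0.19 nM in this assay

Of the two numbers, compound 2 and compound 1 lie within the scatter of each other, as the step of a 1.7-fold higher number from compound 1 to compound 2 (0.24 log units; within the scatter) shows. Compound 3 `CN1CCC[C@H]1COc1cncc(-c2cccs2)c1` differs from compound 2 by thiophen-2-yl in place of furan-2-yl on an aromatic carbon. Among the measured compounds shown here, the only measured step that bears on this change, a 1.7-fold higher number from compound 1 to compound 2 (0.24 log units; within the scatter), replaced one aromatic ring with another and stayed within the scatter; no measured step involves thiophen-2-yl itself. Compound 3 is therefore expected to give about 0.15 nM in this assay, between 0.06 nM and 0.4 nM. For compound 3 this amounts to an expected step of a 1.3-fold lower number from compound 2 to compound 3 (0.10 log units; within the scatter), not beyond the scatter.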

Compound 3, inhibition constant: 0.31 nM
The estimate for compound 3 lay 2.1-fold (0.32 log units) below the measured number; measured number inside the range.
By their numbers in this assay, from the lowest: compounds 1, 2 and 3 (each within the scatter of the next, the first and the last beyond it).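

At this position, thiophen-2-yl in place of furan-2-yl gives a 1.6-fold higher number from compound 2 to compound 3 (0.21 log units; within the scatter) in this assay, so sulfur for oxygen in the five-membered aromatic ring does not move the read-out beyond the scatter. Thiophen-2-yl in place of 4-fluorophenyl gives a 2.8-fold higher number from compound 1 to compound 3 (0.45 log units; beyond the scatter), the only step among these compounds that passes the scatter, and only modestly. Nothing available explains either step. The compounds shown leave open how a non-aromatic group at this position, such as an amine or a carboxylic acid, would read out.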